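From Thiazolyl to Methoxyphenyl on the Saturated Ring Carbon

The source may hold more compounds than are shown below. What is called first, only, known or untested is meant among the compounds shown, and "the series" means these compounds.

Measured so far:
- compound 1, `Cc1cccc(NC(=O)CN2CCC(c3nccs3)CC2)c1`: 62%
- compound 2, `N#Cc1cccc(C(=O)NCN2CCC(c3cccc[n+]3[O-])CC2)c1`: 69%
- compound 3, `O=C(CN1CCC(c2cccc[n+]2[O-])CC1)Nc1cc(Cl)cc(Cl)c1`: 68%

In a functional assay on HEK293 cells for agonist activity at D(4) dopamine receptor (Homo sapiens), read by FLIPR (on this read-out lower numbers stand for smaller maximal responses and higher numbers for larger maximal responses), compound 1 gives the smallest of the three numbers, yet the gaps to compound 3 and to compound 2 both fall within the scatter of repeated measurements, so the three compounds cannot be ranked against each other on these data.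

Compound 4, `COc1ccccc1C1CCN(CC(=O)Nc2cccc(C)c2)CC1`, is built from compound 1 by a single change: 2-methoxyphenyl in place of 1,3-thiazol-2-yl on a saturated ring carbon. The shared core stays untouched; only the group on that saturated ring carbon is swapped. Going by the values given here, no measured pair shows what this particular exchange does in this assay, so the size of the step from compound 1 to compound 4 can only be guessed. With no measured guidance, the plainest expectation is a step that does not clearly exceed the scatter, in either direction. Compound 4 is therefore expected to reach about 65% in this assay, within a range from 45% to 85%. The step of a number 3 percentage points higher from compound 1 to compound 4 (within the scatter) is the expected change behind that estimate.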

Compound 4, largest response reached (reported as efficacy), in percent of the reference or control that the assay uses: 43%
Compound 4: the middle estimate sits 22 percentage points above what was measured; the measured number lies below the stated range.
By their numbers in this assay, from the lowest: compound 4; then compounds 1, 3 and 2 (each within the scatter of the next).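

Going by these compounds alone, putting 2-methoxyphenyl in place of 1,3-thiazol-2-yl on this saturated ring carbon gives a number 19 percentage points lower from compound 1 to compound 4 (beyond the scatter) in this assay and so provides the first evidence that the group at this place can change the maximal response. The earlier compounds shown here could not show this: none of them formed a pair differing in one place, and their numbers all lay within the scatter of one another. No measurement shown here explains the size or direction of this step.

As far as these compounds go, it remains open whether the lower number goes with the methoxy group or with the carbon-only aromatic ring, a question that a plain phenyl group on the same carbon would help to answer. Within the data shown here, with only one pair, it is also open whether the same exchange would give a similar step on a different core.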